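Hydrogen in place of methoxy: compound 2 to compound 3

The compounds below may be only part of what the source reports. "The series", "measured", "known", "first", "only" and "open" are said of these compounds alone.

compound 1 (`COc1cc2oc(=O)cc(-c3ccc4occc4c3)c2c(OC)c1OC`) gives 49000 nM
compound 2 (`COc1ccc(-c2cc(=O)oc3cc(OC)c(OC)c(OC)c23)cn1`) gives > 20000 nM (a limit)

In an ADME assay on HBL-100 cells (Homo sapiens) for cytotoxicity, read by MTT assay, with a stated time of 72 h (on this read-out lower numbers stand for stronger inhibition and higher numbers for weaker inhibition), compound 2 gives only a limit of the assay (> 20000 nM) and no number. Compound 3 (`COc1cc(OC)c2c(-c3ccc(OC)nc3)cc(=O)oc2c1`) has hydrogen in place of methoxy on an aromatic carbon. Within the data shown here, no measured step sizes this change. The expected step (a step that the limit leaves unreadable from compound 2 to compound 3) in this assay stays within the scatter, and any drift is expected toward weaker inhibition. For compound 3 the estimated value is 30000 nM (expected range 10000 nM to 90000 nM).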

Compound 3, half-maximal inhibitory concentration: > 50000 nM
Compound 3: no number, only a limit; the forecaster's own chance of this, stated with the estimate: 50%; middle value at least 1.6-fold (0.22 log units) away from the limit.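

Among these compounds, compound 2 and compound 3 both stand only as limits in this assay, and no step between them can be read. The compounds shown leave open whether hydrogen in place of methoxy on an aromatic carbon changes inhibition at all.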